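The source may report more compounds than this note shows. Statements on the series, on what has been measured and on what is new or still open speak of the compounds shown alone.

Compound 1 `Cc1ccccc1CN1CCc2c(sc(NC(=O)c3ccccc3Cl)c2C(N)=O)C1` carries a 2-methylbenzyl group on the amine nitrogen of the ring that forms part of the shared core. In a functional assay on MKN-74 cells (Homo sapiens) for antiproliferative activity, with a stated time of 24 h (a lower number here means a stronger inhibitor, a higher number a weaker inhibitor), compound 1 gives > 50000 nM, which is a limit of the measurement and not a number (the limit of > 50000 nM in this assay, at which 1 of the 3 values shown sits). Two related compounds with other substituents on the same amine do yield numbers: in this assay compound 2 `Cc1ccc(C(=O)Nc2sc3c(c2C(N)=O)CCN(Cc2c(Cl)cccc2Cl)C3)cc1` gives 12300 nM, and compound 3 `NC(=O)c1c(NC(=O)c2ccccc2F)sc2c1CCN(Cc1cccc(Cl)c1)C2` gives 23300 nM. Compound 4 `Cc1ccccc1NC(=S)N1CCc2c(sc(NC(=O)c3ccccc3Cl)c2C(N)=O)C1` has not yet been measured. It differs from compound 1 in a single place, namely (a group of 10 heavy atoms (8 carbon, 1 nitrogen, 1 sulfur; one six-membered aromatic ring of carbon only) in place of a group of 8 heavy atoms (8 carbon; one six-membered aromatic ring of carbon only), on an amine nitrogen in a ring). Within the data shown here, no measured pair with a change of this kind is available, so any expectation rests on where compound 1 itself stands. Because compound 1 sits at the limit of > 50000 nM in this assay, at which 1 of the 3 values shown sits, the step from compound 1 to compound 4 is expected to be small, with an at least 1.2-fold lower number from compound 1 to compound 4 (0.09 log units; that floor lies within the scatter) judged as a slight gain that may not exceed the usual scatter. Compound 4 is therefore estimated at 40000 nM, within a range from 12000 nM to 100000 nM.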

Compound 4, half-maximal inhibitory concentration: 11700 nM
The estimate for compound 4 lay 3.4-fold (0.53 log units) above the measured number; the whole stated range lies above it.
By their numbers in this assay, from the lowest: compounds 4, 2 and 3 (each within the scatter of the next). At a limit, above all of these: compound 1.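

Swapping the 2-methylbenzyl group on this amine nitrogen for the group containing nitrogen and sulfur gives an at least 4.2-fold lower number from compound 1 to compound 4 (0.63 log units; beyond the scatter) in this assay, so activity in these cells does respond to a change at this position. Among these compounds, compound 2 and compound 3 differ from compound 1 in more than one place, so this is the first comparison that isolates this position. The true size of the step remains unknown because the value for compound 1 is a limit and not a number: the limit of > 50000 nM in this assay, at which 1 of the 4 values shown sits.

The compounds shown cannot separate the contributions of the sulfur, the added nitrogen and the carbon-based aromatic ring within the new group. A urea, with oxygen in place of the sulfur, or a simple acetyl group on the same nitrogen would help to show which part matters.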